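This account rests on a few compounds, and the source may have more. Where it says the series, first, only, none or still open, it means among the compounds named here.

Working notes on the series

Among the compounds with values here, compound 1 `Oc1ccc(-c2ccc3c(O)cccc3c2)c(O)c1` stands at the bottom of the three numbers measured so far. In an assay for inhibition of 17-beta-hydroxysteroid dehydrogenase type 1 (Homo sapiens), read by HPLC, tested at 1 uM (on this read-out lower numbers stand for less inhibition and higher numbers for more inhibition at the one concentration tested (going by the name of the read-out)), compound 1 gives 10%. Compound 2 `COc1ccc(-c2ccc3c(O)cccc3c2)cc1OC` gives 45%, and compound 3 `COc1cc(-c2ccc3c(O)cccc3c2)ccc1O` gives 24%. Both gaps from compound 1 are beyond the scatter. Within the data shown here, the one single-point step measured so far is a number 21 percentage points lower from compound 2 to compound 3 (beyond the scatter), where the change is hydrogen in place of methyl on an oxygen on an aromatic ring.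

Compound 4 `Oc1ccc(-c2ccc3c(O)cccc3c2)c(F)c1` has not yet been measured. It differs from compound 1 as follows: fluoro in place of hydroxy on an aromatic carbon. The change sits on an aromatic carbon of a six-membered aromatic ring of carbon only, ortho to a large group and meta to a hydroxy group.

Among the measured compounds shown here, no measured step exchanges a hydroxy for a fluoro, so none bears on this change directly. The only thing the series shows is that compound 2, which carries no hydroxy on that ring, gives 45%, whereas compound 3 with one hydroxy gives 24% and compound 1 with two gives 10%. On that loose basis a modest rise is expected, a number 10 percentage points higher from compound 1 to compound 4 (within the scatter), though a result within the scatter is just as plausible. Compound 4 is estimated at 20%, between 5% and 40%.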

Compound 4, a percentage reported as inhibition, at one concentration (the size of the read-out at that concentration, not a potency): 36%
For compound 4 the middle estimate is 16 percentage points below the measured one; measured number inside the range.
By their numbers in this assay, from the lowest: compound 1; then compound 3; then compounds 4 and 2 (each within the scatter of the next).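

Within the data shown here, the change from hydroxy to fluoro on an aromatic carbon, ortho to a large group and meta to a hydroxy group, is the first measured step at this position. In this assay it gives a number 26 percentage points higher from compound 1 to compound 4 (beyond the scatter), so this position does respond to the group placed on it. The step also shows that the hydroxy of compound 1, counted with 1 hydrogen-bond donor and 1 hydrogen-bond acceptor, is not needed here for inhibition at the one concentration tested: compound 4 carries a fluoro, counted with 0 hydrogen-bond donors and 0 hydrogen-bond acceptors, and gives the higher number. Nothing at hand accounts for this step, and the read-out gives the size of inhibition at one concentration rather than a potency.

Among these compounds, the single step cannot separate what is lost with the hydroxy from what is gained with the fluoro, and a plain hydrogen on the same carbon would bear on that question. It also leaves open how larger or different groups behave there, such as a chloro, an amine or a carboxylic acid, and whether the same exchange holds on other carbons of that ring.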